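A Methyl Group Replaces the Amino Substituent

A few compounds are considered here, and "the series" means these few. Any claim that something is new, unique, unknown or untested is made for them only; others in the source may bear on it.

In a functional assay on the whole organism with Rattus norvegicus as the target (a lower number here means that less compound is needed, a higher number that more compound is needed for the effect), three compounds differ only in the amino group on an aromatic carbon of the shared core. Compound 1 `CCOC(=O)C(=O)Nc1cccc(N(C)C)c1C#N` gives 4.2 mg/kg, compound 2 `CCCCNc1cccc(NC(=O)C(=O)OCC)c1C#N` gives 0.3 mg/kg, and compound 3 `CCOC(=O)C(=O)Nc1cccc(N(C)C(C)C)c1C#N` gives 1.2 mg/kg, the second highest of the three numbers. Compound 4 `CCOC(=O)C(=O)Nc1cccc(C)c1C#N` has not yet been measured. It carries methyl in place of isopropyl(methyl)amino on an aromatic carbon, ortho to a cyano group (methyl in place of isopropyl(methyl)amino on an aromatic carbon).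

Among the compounds with values here, three measured steps bear on this carbon, and all lie beyond the scatter. Isopropyl in place of methyl on the nitrogen gives a modest step, a 3.5-fold lower number from compound 1 to compound 3 (0.54 log units; beyond the scatter). Butylamino in place of dimethylamino gives a large one, a 14-fold lower number from compound 1 to compound 2 (1.15 log units; beyond the scatter), while isopropyl(methyl)amino in place of butylamino gives a modest one, a 4.0-fold higher number from compound 2 to compound 3 (0.60 log units; beyond the scatter). Within the data shown here, each of these swaps one amino group for another, so no measured step tests the loss of the nitrogen directly. Compound 1, with dimethylamino, has the highest number, and the reverse of a 3.5-fold lower number from compound 1 to compound 3 (0.54 log units; beyond the scatter) suggests that trimming this group raises the number. A modest move to a higher number is therefore expected, with the estimated step being a 2.5-fold higher number from compound 3 to compound 4 (0.40 log units; beyond the scatter). For compound 4 the estimate is 3 mg/kg, with an expected range from 0.8 mg/kg to 11 mg/kg.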

Compound 4, dose for half-maximal effect: 4.6 mg/kg
Estimate against measurement, compound 4: 1.5-fold (0.19 log units) below; low and high end bracket the measured number.
By their numbers in this assay, from the lowest: compound 2; then compound 3; then compounds 1 and 4 (each within the scatter of the next).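

In this assay, within the data shown here, methyl in place of isopropyl(methyl)amino is the first change that removes the nitrogen from this aromatic carbon, and it gives a 3.8-fold higher number from compound 3 to compound 4 (0.58 log units; beyond the scatter), while methyl in place of butylamino gives a 15-fold higher number from compound 2 to compound 4 (1.19 log units; beyond the scatter). Methyl in place of dimethylamino, however, gives a 1.1-fold higher number from compound 1 to compound 4 (0.04 log units; within the scatter), so losing the nitrogen does not by itself set the number: butylamino and isopropyl(methyl)amino stand apart from methyl beyond the scatter, whereas dimethylamino does not. Nothing in the data shown accounts for these differences.

As far as these compounds go, what remains open is whether a butyl or a butoxy group on this carbon would give a number close to that of compound 2 or close to that of compound 4, which would separate the part played by the chain from that of the nitrogen. Also open, from the compounds shown here alone, is whether a short secondary amine such as methylamino or ethylamino would follow butylamino or dimethylamino in this assay's read-out.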